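Methoxybenzyl regioisomer in the platelet inhibition series

The source may hold more compounds than are shown below. What is called first, only, known or untested is meant among the compounds shown, and "the series" means these compounds.

Measured so far:
compound 1 `CCOC(=O)c1ccc(-c2nn(Cc3ccccc3Cl)c3ccccc23)cc1` — > 10000 nM
compound 2 `CCOC(=O)c1ccc(-c2nn(Cc3ccc(F)cc3)c3ccccc23)cc1` — > 10000 nM
compound 3 `CCOC(=O)c1ccc(-c2nn(Cc3ccccc3OC)c3ccccc23)cc1` — > 10000 nM

In a functional assay on cells (Platelet, Homo sapiens) for inhibition (a higher number here means a weaker inhibitor, a lower number a stronger inhibitor), compound 1 gives only the limit of the assay, > 10000 nM. Compound 2 also stands at the assay limit, > 10000 nM. Compound 3 stands at the assay limit as well, > 10000 nM. None of the three values is a number, so the steps among them, a step that the two limits leave unreadable from compound 1 to compound 2, a step that the two limits leave unreadable from compound 1 to compound 3 and a step that the two limits leave unreadable from compound 2 to compound 3, cannot be read; the one point that can be stated is the limit of > 10000 nM in this assay, at which 3 of the 3 values shown sit.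

Compound 4 `CCOC(=O)c1ccc(-c2nn(Cc3cccc(OC)c3)c3ccccc23)cc1` differs from compound 3 by 3-methoxyphenyl in place of 2-methoxyphenyl on a saturated chain carbon bound to an aromatic nitrogen. Among the measured compounds shown here, no measured step covers this change directly. For the measured compounds named here, the three unreadable steps show only that exchanging the group on the saturated chain carbon bound to the aromatic nitrogen among 2-chlorophenyl, 4-fluorophenyl and 2-methoxyphenyl left every compound at the limit, and moving the methoxy within the same ring is a smaller change than any of those. Compound 4 is therefore expected to stay at the limit in this assay, with a step that the limit leaves unreadable from compound 3 to compound 4 expected to be unreadable. The estimate for compound 4 is 20000 nM, with a range from 5000 nM to 100000 nM.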

Compound 4, half-maximal inhibitory concentration: > 10000 nM
Compound 4: only a limit was reported; the forecaster's own chance of this, stated with the estimate: 85%; the middle value is on the limit's open side.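

In this assay compound 4 gives > 10000 nM, a limit and not a number. Its steps from compound 1, compound 2 and compound 3 cannot be read, and one point stands: the limit of > 10000 nM in this assay, at which 4 of the 4 values shown sit. The compounds shown leave open which group on the saturated chain carbon bound to an aromatic nitrogen, if any, would give a measurable value in this assay.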